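From a sulfonamide arm to 4-methylphenyl: an expected gain

This account rests on a few compounds, and the source may have more. Where it says the series, first, only, none or still open, it means among the compounds named here.

Compound 3 `O=C1O[C@H]([C@@H](O)Cn2cc(CNS(=O)(=O)c3ccc(Cl)cc3)nn2)C(OCc2ccccc2)=C1OCc1ccccc1` sits second among three measured compounds: in a functional assay on A549 cells (Homo sapiens) for antiproliferative activity, read by MTT assay, with a stated time of 72 h (a higher number here means a weaker inhibitor, a lower number a stronger inhibitor), compound 3 gives 2870 nM, while compound 1 `O=C1O[C@H]([C@@H](O)Cn2cc(-c3ccc(Br)cc3)nn2)C(OCc2ccccc2)=C1OCc1ccccc1` gives 750 nM and compound 2 `CC(C)(C)c1cn(C[C@H](O)[C@H]2OC(=O)C(OCc3ccccc3)=C2OCc2ccccc2)nn1` gives 34000 nM. Compound 4 `Cc1ccc(-c2cn(C[C@H](O)[C@H]3OC(=O)C(OCc4ccccc4)=C3OCc3ccccc3)nn2)cc1` differs from compound 3 by 4-methylphenyl in place of (((4-chlorophenyl)sulfonyl)amino)methyl on an aromatic carbon. Going by the values given here, two measured steps bear on this change. The step of a 3.8-fold higher number from compound 1 to compound 3 (0.58 log units; beyond the scatter) was modest, whereas a 12-fold lower number from compound 2 to compound 3 (1.07 log units; beyond the scatter) and a 45-fold higher number from compound 1 to compound 2 (1.66 log units; beyond the scatter) were large, showing the non-aromatic tert-butyl to be much weaker than either alternative. Compound 4 carries an aromatic group, as does compound 1 with its 750 nM. For compound 4 a modest move to a lower number is therefore expected in this assay, namely a 2.9-fold lower number from compound 3 to compound 4 (0.46 log units; beyond the scatter). Compound 4 is estimated at 1000 nM, with a range from 300 nM to 3500 nM.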

Compound 4, half-maximal inhibitory concentration: 8690 nM
Beside the measured number, compound 4's estimate is 8.7-fold (0.94 log units) below it, and the stated range ends below it.
By their numbers in this assay, from the lowest: compound 1; then compound 3; then compound 4; then compound 2.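

The phenyl ring alone does not secure strength at this position in this assay: methyl in place of bromo on that ring gives a 12-fold higher number from compound 1 to compound 4 (1.06 log units; beyond the scatter). The sulfonamide arm of compound 3 also outperforms 4-methylphenyl, with a 3.0-fold higher number from compound 3 to compound 4 (0.48 log units; beyond the scatter), though 4-methylphenyl still beats tert-butyl, with a 3.9-fold lower number from compound 2 to compound 4 (0.59 log units; beyond the scatter). No evidence here accounts for these differences. As far as these compounds go, it remains open how chloro or methoxy in place of bromo on the same phenyl ring would compare. An amine or a carboxylic acid on that ring is equally untested among the compounds shown.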